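Enlarging the Ring-Nitrogen Substituent of Compound 2

The source may hold more compounds than are shown below. What is called first, only, known or untested is meant among the compounds shown, and "the series" means these compounds.

Compound 1 `Cc1nn(C)c2c1C(c1ccccc1)=NCC(=O)N2` and compound 2 `Cc1nn(C)c2c1C(c1ccccc1Cl)=NCC(=O)N2` share one core. In a functional assay on the whole organism with Rattus norvegicus as the target (on this read-out higher numbers stand for an effect only at larger amounts of compound and lower numbers for an effect already at smaller amounts), compound 1 gives 16 mg/kg and compound 2 gives 16 mg/kg, so the step of no change at the digits printed from compound 1 to compound 2 (within the scatter) leaves the read-out where it was, and compound 2 stands level with compound 1. Compound 3 `CCCCc1nn(C)c2c1C(c1ccccc1Cl)=NCC(=O)N2` is reached by the step of an at least 31-fold higher number from compound 2 to compound 3 (1.49 log units; beyond the scatter). In this assay compound 3 gives only a limit of > 500 mg/kg. Compound 3 thus sits at the limit of > 500 mg/kg in this assay, at which 1 of the 3 values shown sits.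

Compound 4 `Cc1nn(C(C)C)c2c1C(c1ccccc1Cl)=NCC(=O)N2` carries the change (isopropyl in place of methyl on an aromatic nitrogen). Going by the values given here, no measured step alters the group on this aromatic nitrogen, so the only guide is the step of an at least 31-fold higher number from compound 2 to compound 3 (1.49 log units; beyond the scatter), in which a larger group was likewise placed on the core, though at a different position. The change in compound 4 is smaller, and a modest step toward higher doses is expected, a 3.1-fold higher number from compound 2 to compound 4 (0.49 log units; beyond the scatter), with real uncertainty about whether the read-out ends at a limit. Compound 4 is therefore estimated at 50 mg/kg, between 16 mg/kg and 250 mg/kg.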

Compound 4, minimum effective dose: 16 mg/kg
Estimate against measurement, compound 4: 3.1-fold (0.49 log units) above; measured number inside the range.
By their numbers in this assay, from the lowest: compounds 1, 2 and 4 (each within the scatter of the next). At a limit, above all of these: compound 3.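

In this assay, going by these compounds alone, isopropyl in place of methyl on an aromatic nitrogen gives no change at the digits printed from compound 2 to compound 4 (within the scatter), the first reading of a change at this nitrogen. Enlarging a group on the shared core therefore does not have the same outcome everywhere, since propyl in place of hydrogen on a saturated chain carbon bound to an aromatic carbon gave an at least 31-fold higher number from compound 2 to compound 3 (1.49 log units; beyond the scatter). Compound 3 has a limit rather than a number: the limit of > 500 mg/kg in this assay, at which 1 of the 4 values shown sits.

From the compounds shown here alone, whether the read-out would hold with anything larger on this nitrogen stays open, for instance a longer chain such as butyl, a benzyl group or a chain ending in an amine. Also open, going by these compounds, is whether isopropyl would leave the read-out unchanged on compound 1, which has hydrogen in place of the chloro.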